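Swapping a carbamoylphenyl for naphthyl on an adenosine-based scaffold

The compounds below may be only part of what the source reports. "The series", "measured", "known", "first", "only" and "open" are said of these compounds alone.

Compound 1, `NC(=O)CCCN(Cc1cccc(C(N)=O)c1)C[C@H]1O[C@@H](n2cnc3c(N)ncnc32)[C@H](O)[C@@H]1O`, in an assay on cells for inhibition of Nicotinamide N-methyltransferase (Homo sapiens), with stated times of 10 min and 30 min; on this read-out lower numbers stand for stronger inhibition and higher numbers for weaker inhibition: > 250000 nM, a limit of the assay.
Compound 2, `NC(=O)c1cccc(CN(CCCC(=O)O)C[C@H]2O[C@@H](n3cnc4c(N)ncnc43)[C@H](O)[C@@H]2O)c1`, in this assay: > 250000 nM, a limit of the assay.
Compound 3, `NC(=O)c1cccc(CN(CCCCC(=O)O)C[C@H]2O[C@@H](n3cnc4c(N)ncnc43)[C@H](O)[C@@H]2O)c1`, in this assay: > 250000 nM, a limit of the assay.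

Compound 1 stands only at a limit, as do the other two; this is summed up in the limit of > 250000 nM in this assay, at which 3 of the 3 values shown sit. The three measured steps, a step that the two limits leave unreadable from compound 1 to compound 2, a step that the two limits leave unreadable from compound 1 to compound 3 and a step that the two limits leave unreadable from compound 2 to compound 3, therefore give no readable size.

Compound 4, `NC(=O)CCCN(Cc1ccc2ccccc2c1)C[C@H]1O[C@@H](n2cnc3c(N)ncnc32)[C@H](O)[C@@H]1O`, differs from compound 1 in one place: naphthalen-2-yl in place of 3-carbamoylphenyl on a saturated chain carbon bound to an amine nitrogen. Among the measured compounds shown here, none of the measured steps touches this part of the molecule, so they offer no guide to the size or direction of the step. With every measured compound at the limit, compound 4 is expected near it as well, estimated at 200000 nM with a range from 30000 nM to 250000 nM, which would mean a step of an at least 1.2-fold lower number from compound 1 to compound 4 (0.09 log units; that floor lies within the scatter).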

Compound 4, half-maximal inhibitory concentration: 112000 nM
Compound 4: middle estimate off by 1.8-fold (0.25 log units), on the high side; low and high end bracket the measured number.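

In this assay the change on a saturated chain carbon bound to an amine nitrogen gives an at least 2.2-fold lower number from compound 1 to compound 4 (0.34 log units; beyond the scatter) and so shows that this position can move the read-out. The earlier steps shown here, all on the other chain, cannot be read. Compound 4 is the only compound here with a number rather than a limit: the limit of > 250000 nM in this assay, at which 3 of the 4 values shown sit.

A plain benzyl group in this place would help separate the loss of the carbamoyl from the added ring. As far as these compounds go, it also remains open whether naphthalen-2-yl acts the same way alongside the carboxylic acid chains of compound 2 and compound 3.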